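Exchanging the amide substituent while the rest stays fixed

A few compounds are considered here, and "the series" means these few. Any claim that something is new, unique, unknown or untested is made for them only; others in the source may bear on it.

Compounds measured so far:
compound 1 `Cc1cccc(Oc2ccnc(N3CCC[C@H]3C(=O)NCc3cccnc3)n2)c1`: 0%
compound 2 `Cc1cccc(Oc2ccnc(N3CCC[C@H]3C(=O)NCCCn3ccnc3)n2)c1`: 0%
compound 3 `COC[C@@H]1CCCN1C(=O)[C@@H]1CCCN1c1cc(Nc2cccc(OC)c2)nc(N)n1`: 0%

In an assay on isolated protein for inhibition of RAC-alpha serine/threonine-protein kinase (Homo sapiens), read by HTRF, tested at 10 uM (on this read-out higher numbers stand for more inhibition at the one concentration tested (going by the name of the read-out) and lower numbers for less inhibition), compound 1 gives 0%, compound 2 gives 0% and compound 3 gives 0%. Compound 2 thus stands level with compound 1 and compound 3 at the digits shown, and the only step between neighbours, no change at the digits printed from compound 1 to compound 2 (within the scatter), was no change within the scatter.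

Compound 4 `COC(=O)C(CO)NC(=O)[C@@H]1CCCN1c1nccc(Oc2cccc(C)c2)n1` follows from compound 2 by a further exchange at the same place: 2-hydroxy-1-(methoxycarbonyl)ethyl in place of 3-(1H-imidazol-1-yl)propyl on an amide-type nitrogen. Going by the values given here, the single measured step that bears on this position, no change at the digits printed from compound 1 to compound 2 (within the scatter), showed that swapping one substituent on the amide-type nitrogen for another left the read-out where it was; compound 3, with a different core, sits at the same level. On that basis no step beyond the scatter is expected for this assay. The expected step is a number 2 percentage points higher from compound 2 to compound 4 (within the scatter), a flat one. Compound 4 is estimated to give 2%, between -8% and 12%.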

Compound 4, a percentage reported as inhibition, at one concentration (the size of the read-out at that concentration, not a potency): 0%
The estimate for compound 4 lay 2 percentage points above the measured number, and the stated range covers the measured number.
By their numbers in this assay, from the lowest: compounds 1, 2, 3 and 4 (each within the scatter of the next).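

In this assay, the exchange on the amide-type nitrogen now extends to a substituent with no ring: 2-hydroxy-1-(methoxycarbonyl)ethyl in place of 3-(1H-imidazol-1-yl)propyl brings no change at the digits printed from compound 2 to compound 4 (within the scatter), and in place of (pyridin-3-yl)methyl it brings no change at the digits printed from compound 1 to compound 4 (within the scatter). The earlier step at this place compared only two substituents that each carry an aromatic ring, so the flat result now also covers an open chain with hydroxy and methoxycarbonyl groups. Nothing available here explains why the read-out stays flat at this position.

It remains open whether an amine, a carboxylic acid or a longer chain on the amide-type nitrogen would raise the read-out above that of these compounds. Going by these compounds, whether a change elsewhere on the shared core would do so also remains open.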